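The source may report more compounds than this note shows. Statements on the series, on what has been measured and on what is new or still open speak of the compounds shown alone.

Compound 3 `CC(C)C(c1noc(=O)[nH]1)c1ccc(-c2ccc3cccc(F)c3c2)[nH]c1=O` carries the highest number of the three measured compounds: in an assay on CHO cells for displacement of a labelled ligand from prostaglandin E2 receptor EP3 subtype (Homo sapiens), read by radioligand binding (a lower number here means a stronger inhibitor, a higher number a weaker inhibitor), compound 3 gives 15 nM, whereas compound 1 `CC(C)C(c1ncc[nH]1)c1ccc(-c2ccc3cccc(F)c3c2)[nH]c1=O` gives 7.3 nM and compound 2 `CC(C)C(Nc1nccs1)c1ccc(-c2ccc3cccc(F)c3c2)[nH]c1=O` gives 9.4 nM. Compound 4 `CC(C)C(c1ccc(-c2ccc3cccc(F)c3c2)[nH]c1=O)N1CCCCS1(=O)=O` differs from compound 3 by a group of 8 heavy atoms (4 carbon, 1 nitrogen, 2 oxygen, 1 sulfur; one six-membered non-aromatic ring with 2 hetero atoms) in place of a group of 6 heavy atoms (2 carbon, 2 nitrogen, 2 oxygen; one five-membered aromatic ring with 3 hetero atoms), on a saturated chain carbon bound to an aromatic carbon and a saturated chain carbon. Within the data shown here, the steps that bear on this position are a 2.1-fold higher number from compound 1 to compound 3 (0.31 log units; beyond the scatter), a 1.6-fold higher number from compound 2 to compound 3 (0.20 log units; within the scatter) and a 1.3-fold higher number from compound 1 to compound 2 (0.11 log units; within the scatter), all small, so the three replacements tried on this saturated chain carbon have moved the number little. Among the measured compounds shown here, the entering group, one six-membered non-aromatic ring with 2 hetero atoms and 0 hydrogen-bond donors, is unlike anything measured here, and no step covers it. Compound 4 is therefore expected to shift by a 2.0-fold higher number from compound 3 to compound 4 (0.30 log units; within the scatter), with an estimated value of 30 nM, ranging from 8 nM to 120 nM.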

Compound 4, inhibition constant: 14 nM
Estimate against measurement, compound 4: 2.1-fold (0.33 log units) above; low and high end bracket the measured number.
By their numbers in this assay, from the lowest: compounds 1, 2, 4 and 3 (each within the scatter of the next, the first and the last beyond it).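

In this assay, the six-membered non-aromatic ring with 2 hetero atoms and 0 hydrogen-bond donors fits the pattern of the aromatic groups on this saturated chain carbon: a 1.1-fold lower number from compound 3 to compound 4 (0.03 log units; within the scatter), a 1.5-fold higher number from compound 2 to compound 4 (0.17 log units; within the scatter) and a 1.9-fold higher number from compound 1 to compound 4 (0.28 log units; within the scatter). Among these four compounds, then, a non-aromatic group of 8 heavy atoms changes the number by no more than the scatter from any of the three aromatic groups. Nothing available explains this result.

From the compounds shown here alone, whether a primary amine or a carboxylic acid on this carbon would leave the number as little changed remains open. So does whether an open-chain sulfonamide would match the ring.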